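The compounds below may be only part of what the source reports. "The series", "measured", "known", "first", "only" and "open" are said of these compounds alone.

Measured so far in a functional assay on MGC-803 cells (Homo sapiens) for cytotoxicity, read by MTT assay, with a stated time of 48 h; on this read-out lower numbers stand for stronger inhibition and higher numbers for weaker inhibition:
compound 1 `C=CCN(CC=C)CC(=O)N1N=C(C)CC1c1cc(Br)ccc1O` gives 10200 nM
compound 2 `CCC(=O)N1N=C(c2cc3ccccc3oc2=O)CC1c1ccccc1` gives 5300 nM

Compound 2 gives the lower of the two numbers, but the gap to compound 1 lies within the usual scatter, so no order between them is claimed. Compound 3 `NC(=O)C1CCN(CC(=O)N2N=C(c3cc4ccccc4oc3=O)CC2c2ccccc2)CC1` differs from compound 2 by 4-carbamoylpiperidin-1-yl in place of methyl on a saturated chain carbon bound to a carbonyl carbon. Among the measured compounds shown here, no measured pair shows a change of this kind, so nothing here tells how large a step it brings. In this assay the expected step is a 1.2-fold lower number from compound 2 to compound 3 (0.07 log units; within the scatter), none beyond the scatter. Compound 3 is estimated at 4500 nM, with a range from 1500 nM to 13000 nM.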

Compound 3, half-maximal inhibitory concentration: 21500 nM
Estimate against measurement, compound 3: 4.8-fold (0.68 log units) below; the measured number lies above the stated range.
By their numbers in this assay, from the lowest: compounds 2 and 1 (each within the scatter of the next); then compound 3.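

In this assay, among the compounds shown here, the saturated chain carbon bound to a carbonyl carbon responds to substitution: 4-carbamoylpiperidin-1-yl in place of methyl brings a 4.1-fold higher number from compound 2 to compound 3 (0.61 log units; beyond the scatter) and thus the first step beyond the scatter. On the shared core, this larger group gives weaker inhibition than methyl. Nothing available explains the loss.

Still open, on these data alone, is whether the loss follows the six-membered ring or its carbamoyl group. A plain piperidin-1-yl, a dimethylamino group or a longer alkyl chain at this carbon would separate these readings.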